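The source may report more compounds than this note shows. Statements on the series, on what has been measured and on what is new or still open speak of the compounds shown alone.

Measured so far in a functional assay on HCT-116 cells (Homo sapiens), read by MTT assay, with a stated time of 72 h; on this read-out lower numbers stand for stronger inhibition and higher numbers for weaker inhibition; each value is a limit of the assay:

- Compound 1 `C#Cc1cn([C@@H]2O[C@H](CO)[C@@H](O)[C@H]2O)c2ncnc(C)c12`: > 20000 nM
- Compound 2 `Nc1nc(N)c2c(-c3ccco3)cn([C@@H]3O[C@H](CO)[C@@H](O)[C@H]3O)c2n1`: > 20000 nM
- Compound 3 `Cc1nc(N)c2c(-c3ccco3)cn([C@@H]3O[C@H](CO)[C@@H](O)[C@H]3O)c2n1`: > 20000 nM

Compound 3 gives > 20000 nM, which is a limit and not a number. The same holds across the small set, as the limit of > 20000 nM in this assay, at which 3 of the 3 values shown sit, shows. Compound 4 `Cc1nc(N)c2c(-c3cc4ccccc4o3)cn([C@@H]3O[C@H](CO)[C@@H](O)[C@H]3O)c2n1` carries 1-benzofuran-2-yl in place of furan-2-yl on an aromatic carbon of a five-membered aromatic ring with 1 nitrogen, and the counted difference is 1-benzofuran-2-yl in place of furan-2-yl on an aromatic carbon.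

Within the data shown here, the only measured step is a step that the two limits leave unreadable from compound 2 to compound 3. It concerns methyl in place of amino, not the present change, and it has no readable size to carry over. No measured number therefore supports a definite step in this assay or a firm direction. Compound 4 is expected to stay close to the limit of compound 3, though a measurable value remains possible. The expected change is a number no higher from compound 3 to compound 4 (the limit leaves the size open). Compound 4 is estimated at 20000 nM, with an expected range of 6000 nM to 50000 nM.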

Compound 4, half-maximal inhibitory concentration: 13100 nM
For compound 4 the middle estimate is 1.5-fold (0.18 log units) above the measured one; the range from low to high includes it.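

In this assay, among these compounds, compound 4 gives 13100 nM, the only actual number in this set, so a group at this position can bring the reading into the measurable range. Compound 3 gives > 20000 nM, which is a limit. Placing 1-benzofuran-2-yl in place of furan-2-yl gives an at least 1.5-fold lower number from compound 3 to compound 4 (0.18 log units; that floor lies within the scatter), so the true size of the change stays unknown, and the floor alone does not establish a real gain; the set offers little else to compare with, as most of its values are not numbers: the limit of > 20000 nM in this assay, at which 3 of the 4 values shown sit.

The compounds shown leave open whether an amine, a carboxylic acid or a longer chain at this position would give a lower number than compound 4. From the compounds shown here alone, it is also open whether the result for 1-benzofuran-2-yl would hold with amino in place of methyl on the shared core.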